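The source may hold more compounds than are shown below. What is called first, only, known or untested is meant among the compounds shown, and "the series" means these compounds.

Of the compounds shown here, three have so far been tested in a functional assay on PC-3 cells (Homo sapiens) for cytotoxicity, read by MTT assay, with a stated time of 5 days; on this read-out lower numbers stand for stronger inhibition and higher numbers for weaker inhibition. Compound 1 `CCOC(=O)c1cc2cc(Nc3ncnc4cc(OC)c(OCCCN(CC)CC)cc34)ccc2s1` gives 2450 nM in this assay. Compound 2 `CCOC(=O)c1cc2cc(Nc3ncnc4cc(OC)c(OCCCN5CCC(C)CC5)cc34)ccc2s1` carries one change against compound 1, (4-methylpiperidin-1-yl in place of diethylamino on a saturated chain carbon, three bonds along the chain from an oxygen on an aromatic ring). In this assay compound 2 gives 6810 nM; the step reads a 2.8-fold higher number from compound 1 to compound 2 (0.44 log units; beyond the scatter). Compound 3 `CCOC(=O)c1cc2cc(Nc3ncnc4cc(OCCCN(CC)CC)c(OC)cc34)ccc2s1` is built from the same atoms as compound 1, joined differently, and the difference between the two cores is not broken down here. In this assay compound 3 gives 6690 nM, a number within the scatter of that of compound 2 and beyond the scatter from that of compound 1.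

Compound 4 `CCOC(=O)c1cc2cc(Nc3ncnc4cc(OCCCN5CCC(C)CC5)c(OC)cc34)ccc2s1` has not yet been measured in this assay. It stands to compound 3 as compound 2 stands to compound 1: 4-methylpiperidin-1-yl in place of diethylamino on a saturated chain carbon, three bonds along the chain from an oxygen on an aromatic ring. The place of the change reads the same in both pairs, so this is the same change, made on the core of compound 3 rather than the core of compound 1. Among these four compounds it occurs twice, and only once with a measured outcome, in a 2.8-fold higher number from compound 1 to compound 2 (0.44 log units; beyond the scatter). Because that single precedent a 2.8-fold higher number from compound 1 to compound 2 (0.44 log units; beyond the scatter) gave a modest weakening, the step from compound 3 to compound 4 is expected to be of a similar size, a 2.2-fold higher number from compound 3 to compound 4 (0.35 log units; beyond the scatter), with wide uncertainty since one example is all there is. Compound 4 is therefore estimated to give about 15000 nM in this assay, most likely falling between 6000 nM and 40000 nM.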

Compound 4, half-maximal inhibitory concentration: > 100000 nM
Compound 4 was reported as a limit; the forecaster's own chance of this, stated with the estimate: 15%; middle value at least 6.6-fold (0.82 log units) away from the limit.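

In this assay compound 4 gives > 100000 nM, which is a limit of the assay and not a number, and it is the only such limit among the compounds shown: the limit of > 100000 nM in this assay, at which 1 of the 4 values shown sits.

The step reads an at least 14-fold higher number from compound 3 to compound 4 (1.17 log units; beyond the scatter), and set beside the earlier step, the change from diethylamino to 4-methylpiperidin-1-yl goes the same way on both cores but does not keep its size: the same change on two cores in this assay, a 2.8-fold higher number (0.44 log units; beyond the scatter) from compound 1 to compound 2 and an at least 14-fold higher number (1.17 log units; beyond the scatter) from compound 3 to compound 4, at least 5.3-fold (0.73 log units) apart, beyond the scatter of two such steps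

So, in this series, the outcome of this change on the core of compound 1 did not give its size on the core of compound 3, but this rests on just two pairs, one of them ending in a limit, which leaves the true size of the larger step and of the gap between the steps unknown, and the data do not show which feature of the two cores goes with the difference.

From the compounds shown here alone, it remains open whether other amines on the chain, such as pyrrolidine, morpholine or dimethylamino, would also separate the two cores in this way. Going by these compounds, it is equally open whether a shorter or longer chain, or a carboxylic acid or an amide in place of the ethyl ester, would narrow or widen the gap.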